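This account rests on a few compounds, and the source may have more. Where it says the series, first, only, none or still open, it means among the compounds named here.

In a functional assay on MOLT-4 cells (Homo sapiens) for antiproliferative activity, with a stated time of 48 h (a higher number here means a weaker inhibitor, a lower number a stronger inhibitor), the fluoro compound 1 `Nc1ccc(/C=C/C(=O)c2ccc(F)cc2)cc1` gives 12000 nM and the chloro compound 2 `Nc1ccc(/C=C/C(=O)c2ccc(Cl)cc2)cc1` gives 7800 nM, while the iodo compound 3 `Nc1ccc(/C=C/C(=O)c2ccc(I)cc2)cc1` gives 7500 nM on the same shared core. Compound 3 stands level with the other two: the steps are a 1.0-fold lower number from compound 2 to compound 3 (0.02 log units; within the scatter) and a 1.6-fold lower number from compound 1 to compound 3 (0.20 log units; within the scatter) and neither exceeds the usual scatter.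

Compound 4 `Cc1ccc(C(=O)/C=C/c2ccc(N)cc2)cc1` differs from compound 3 by methyl in place of iodo on an aromatic carbon. The closest evidence comes from the swaps at this same place. Besides the two steps already given, the data show a 1.5-fold lower number from compound 1 to compound 2 (0.19 log units; within the scatter) and this one also stays within the scatter. For the measured compounds named here, no methyl compound has been measured yet, so these halogen swaps are only a loose guide.

In this assay no step beyond the scatter is therefore expected, and neither direction is favoured. The estimated step is a 1.1-fold higher number from compound 3 to compound 4 (0.05 log units; within the scatter) and would count as no real change. For compound 4 the estimated value is 8500 nM with an expected range from 4500 nM to 16000 nM in this measurement.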

Compound 4, half-maximal inhibitory concentration: 12000 nM
Estimate against measurement, compound 4: 1.4-fold (0.15 log units) below; the measured number falls inside the stated range.
By their numbers in this assay, from the lowest: compounds 3, 2, 1 and 4 (each within the scatter of the next).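

In this assay, for the compounds shown here, methyl, the first group at this position that is not a halogen, gives a 1.6-fold higher number from compound 3 to compound 4 (0.20 log units; within the scatter) and a 1.5-fold higher number from compound 2 to compound 4 (0.19 log units; within the scatter) and no change at the digits printed from compound 1 to compound 4 (within the scatter) so it stands level with all three halogen compounds. The earlier compounds shown here showed only that halogens could be exchanged here without a step beyond the scatter; compound 4 extends this observation to a small carbon group on the same aromatic carbon. No measured information shown here offers an explanation for this result.

From the compounds shown here alone, it remains open whether a larger or different kind of group at this place, such as a methoxy group, a carboxylic acid or a longer alkyl chain, would give a step beyond the scatter. Going by these compounds, how changes elsewhere on the shared core would affect the number also remains open.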